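Methoxy for Fluoro on a Methylsulfonyl Aniline Core

A few compounds are considered here, and "the series" means these few. Any claim that something is new, unique, unknown or untested is made for them only; others in the source may bear on it.

Within the data shown here, in an assay for binding affinity to Alpha-1A adrenergic receptor (Homo sapiens), read by radioligand binding (on this read-out lower numbers stand for stronger inhibition and higher numbers for weaker inhibition), compound 3 `CS(=O)(=O)c1ccc(F)cc1NCC1=NCCN1` gives 813 nM, the highest of the three numbers measured so far. Compound 1 `CSc1ccc(F)cc1NCC1=NCCN1` gives 33.1 nM and compound 2 `CS(=O)(=O)c1ccc(Cl)cc1NCC1=NCCN1` gives 537 nM. The switch from methylsulfanyl to methylsulfonyl was large: a 25-fold higher number from compound 1 to compound 3 (1.39 log units; beyond the scatter). Exchanging one halogen for another moved little: a 1.5-fold higher number from compound 2 to compound 3 (0.18 log units; within the scatter). Compound 4 `COc1ccc(S(C)(=O)=O)c(NCC2=NCCN2)c1` differs from compound 3 at one place: methoxy in place of fluoro on an aromatic carbon. Among the measured compounds shown here, no measured pair tests methoxy against fluoro, so the only guide is the halogen exchange, which stayed within the scatter. The step to compound 4 is therefore expected to be small: a 1.2-fold lower number from compound 3 to compound 4 (0.06 log units; within the scatter). Compound 4 is expected to give about 700 nM, within a range from 200 nM to 2500 nM.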

Compound 4, inhibition constant: 1620 nM
Beside the measured number, compound 4's estimate is 2.3-fold (0.36 log units) below it, within the range that was stated.
By their numbers in this assay, from the lowest: compound 1; then compounds 2, 3 and 4 (each within the scatter of the next, the first and the last beyond it).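

At this position, para to the methylsulfonyl group, methoxy in place of fluoro gives a 2.0-fold higher number from compound 3 to compound 4 (0.30 log units; within the scatter) and so stays within the scatter. Methoxy in place of chloro gives a 3.0-fold higher number from compound 2 to compound 4 (0.48 log units; beyond the scatter) and goes beyond it, so a group other than a halogen brings no lower number here. No measurement available here explains these steps. As far as these compounds go, whether an amine or a longer chain such as ethoxy at this position would lower the number remains open. Also open, from the compounds shown here alone, is whether methoxy would act the same way with methylsulfanyl in place of methylsulfonyl.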